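Opening the azetidine amide into a fluorobenzyl amide

The source may report more compounds than this note shows. Statements on the series, on what has been measured and on what is new or still open speak of the compounds shown alone.

The measured compounds:
- Compound 1 `CCN1CCN(C(=O)C[C@H](Cc2ccc(Cl)cc2)C(=O)N2CCN(c3ccccc3N(CC3CC3)S(C)(=O)=O)CC2)CC1`: in a functional assay with Melanocortin receptor 4 (Homo sapiens) as the target, read by cAMP accumulation (a higher number here means that more compound is needed for the effect, a lower number that less compound is needed), compound 1 gives only a limit, > 10000 nM.
- Compound 2 `CS(=O)(=O)N(CC1CC1)c1ccccc1N1CCN(C(=O)[C@H](CC(=O)N2CCN(C(=O)c3ccccc3)CC2)Cc2ccc(Cl)cc2)CC1`: in this assay compound 2 gives 83 nM.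
- Compound 3 `CCN(C(C)=O)C(C)c1ccccc1N1CCN(C(=O)[C@H](CC(=O)N2CCC2)Cc2ccc(Cl)cc2)CC1`: in this assay compound 3 gives 340 nM.

Compound 3 has the highest of the two real numbers shown; compound 2 sits below it, and compound 1 sits at the limit of the assay (the limit of > 10000 nM in this assay, at which 1 of the 3 values shown sits). Going by the values given here, the one step measured between neighbours, an at least 120-fold lower number from compound 1 to compound 2 (2.08 log units; beyond the scatter), came from swapping a benzoyl in place of ethyl on an amine nitrogen in a ring, a site elsewhere in the molecule.

Compound 4 `CCN(C(C)=O)C(C)c1ccccc1N1CCN(C(=O)[C@H](CC(=O)NCc2ccccc2F)Cc2ccc(Cl)cc2)CC1` differs from compound 3 in one place: (2-fluorobenzyl)amino in place of azetidin-1-yl on a carbonyl carbon. Among the compounds with values here, no measured step touches this position, and compounds 2 and 3 differ in several places at once, so neither gives a direct guide. The gap between compound 3 and compound 2 does show that a larger aromatic group in this part of the molecule can go with a lower number. A modest decrease is therefore expected, a 1.7-fold lower number from compound 3 to compound 4 (0.23 log units; within the scatter), and compound 4 is estimated at 200 nM, between 50 nM and 1500 nM.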

Compound 4, half-maximal effective concentration: 89 nM
Compound 4: middle estimate off by 2.2-fold (0.35 log units), on the high side, and the stated range covers the measured number.
By their numbers in this assay, from the lowest: compounds 2 and 4 (each within the scatter of the next); then compound 3. At a limit, above all of these: compound 1.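

Swapping azetidin-1-yl for (2-fluorobenzyl)amino on this carbonyl carbon gives, in this assay, a 3.8-fold lower number from compound 3 to compound 4 (0.58 log units; beyond the scatter), the first measured change at this position. It shows that the position accepts a much larger group, with 9 heavy atoms in place of 4, and that the number responds to what sits there. The entering group also brings an aromatic ring and a hydrogen-bond donor, and this single pair cannot separate those features from one another or from size, nor does anything measured here give a cause for the change.

Still open, as far as these compounds go, is whether the fluorine matters, which a plain benzylamino group would test. Also open, from the compounds shown here alone, is whether the amide hydrogen matters, which (2-fluorobenzyl)(methyl)amino would test, and how a longer chain leading to the ring would read.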